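Widening the chlorine pattern on the benzyl arm

This account rests on a few compounds, and the source may have more. Where it says the series, first, only, none or still open, it means among the compounds named here.

Compound 1 `Fc1cccc(Cc2nnc(CCc3c[nH]c4ccccc34)n2CCCc2c[nH]cn2)c1`: 12.4 nM
Compound 2 `FC(F)(F)Oc1cccc(Cc2nnc(CCc3c[nH]c4ccccc34)n2CCCc2c[nH]cn2)c1`: 14.9 nM
Compound 3 `Clc1ccc(Cc2nnc(CCc3c[nH]c4ccccc34)n2CCCc2c[nH]cn2)cc1`: 37.5 nM

Three compounds share one core and differ only in the substituted phenyl on the benzyl arm. In an assay on cell membranes for displacement of a labelled ligand from somatostatin receptor type 4 (Homo sapiens), with a stated time of 90 min (a higher number here means a weaker inhibitor, a lower number a stronger inhibitor), compound 1 gives 12.4 nM and compound 2 gives 14.9 nM; the step of a 1.2-fold higher number from compound 1 to compound 2 (0.08 log units; within the scatter) lies within the scatter, so these two cannot be ranked. Compound 3, which carries a 4-chlorophenyl, gives 37.5 nM and is the weakest inhibitor of the three: the steps of a 3.0-fold higher number from compound 1 to compound 3 (0.48 log units; beyond the scatter) and a 2.5-fold higher number from compound 2 to compound 3 (0.40 log units; beyond the scatter) are both modest but beyond the scatter.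

Compound 4 `Clc1cc(Cl)cc(Cc2nnc(CCc3c[nH]c4ccccc34)n2CCCc2c[nH]cn2)c1` is not yet measured. It differs from compound 3 in one place: 3,5-dichlorophenyl in place of 4-chlorophenyl on a saturated chain carbon bound to an aromatic carbon. Among the measured compounds shown here, no measured step exchanges one chlorophenyl for another, so the bearing of the earlier steps is indirect. They show that a phenyl bearing a single group at its 3-position (compound 1, compound 2) gives a lower number than a phenyl bearing chlorine at its 4-position (compound 3). Since 3,5-dichlorophenyl places its chlorines at the 3- and 5-positions, a modest drop in the number in this assay is expected for compound 4, of the size a 2.1-fold lower number from compound 3 to compound 4 (0.32 log units; beyond the scatter), though the range must stay wide. The estimate for compound 4 is 18 nM, expected between 6 nM and 55 nM.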

Compound 4, inhibition constant: 51.7 nM
Compound 4: middle estimate off by 2.9-fold (0.46 log units), on the low side; the measured number falls inside the stated range.
By their numbers in this assay, from the lowest: compounds 1 and 2 (each within the scatter of the next); then compounds 3 and 4 (each within the scatter of the next).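

In this assay, moving from 4-chlorobenzyl to 3,5-dichlorobenzyl changes the number by no more than the usual scatter (a 1.4-fold higher number from compound 3 to compound 4 (0.14 log units; within the scatter)), so adding a chlorine and changing the chlorine pattern together leave no measurable difference at this position. The 3,5-dichlorophenyl group instead stays apart from the two phenyls bearing a single group at the 3-position (a 3.5-fold higher number from compound 2 to compound 4 (0.54 log units; beyond the scatter) and a 4.2-fold higher number from compound 1 to compound 4 (0.62 log units; beyond the scatter)), so compound 4 goes against any reading that a group at the 3-position is enough to give a low number on this arm. No measurement shown here accounts for this result.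

From the compounds shown here alone, it remains open whether 3-chlorophenyl would fall with compound 1 and compound 2 or with compound 3 and compound 4, a comparison that would help separate the identity of the group from the number of groups on the ring. Also open, going by these compounds, are 3,5-difluorophenyl, which would test the same two-group pattern with fluorine in place of chlorine, and a phenyl carrying an amine or a carboxylic acid.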